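Benzoxazolone acetamides: pyridin-2-yl amide on the chloro core

A few compounds are considered here, and "the series" means these few. Any claim that something is new, unique, unknown or untested is made for them only; others in the source may bear on it.

Measured compounds in an ADME assay on RAW264.7 cells (Mus musculus) for cytotoxicity, read by MTT assay, with a stated time of 72 h, tested at 100 uM; a higher number here means a stronger effect of the compound at the concentration tested, a lower number a weaker effect:
compound 1 `O=C(Cn1c(=O)oc2cc([N+](=O)[O-])ccc21)Nc1ccccn1` gives 47.3%
compound 2 `O=C(Cn1c(=O)oc2cc(Cl)ccc21)Nc1ccccc1` gives 20.2%
compound 3 `O=C(Cn1c(=O)oc2cc([N+](=O)[O-])ccc21)Nc1ccccc1` gives 26.4%

Compound 2 has the lowest number of the three; compound 3 lies within the scatter of it, compound 1 sits beyond the scatter above it. The step from compound 2 to compound 4 `O=C(Cn1c(=O)oc2cc(Cl)ccc21)Nc1ccccn1` is pyridin-2-yl in place of phenyl on an amide-type nitrogen. Within the data shown here, the one measured step of this kind runs the other way: a number 20.9 percentage points lower from compound 1 to compound 3 (beyond the scatter). The other step, a number 6.2 percentage points higher from compound 2 to compound 3 (within the scatter), shows that nitro against chloro on the core shifts little, so the step on the nitro pair is taken as the guide. Compound 4 is therefore expected to rise by about a number 20.8 percentage points higher from compound 2 to compound 4 (beyond the scatter). Compound 4 is estimated at 41%, within 26% to 56%.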

Compound 4, a percentage reported as inhibition, at one concentration (the size of the read-out at that concentration, not a potency): 43.7%
For compound 4 the middle estimate is 2.7 percentage points below the measured one; low and high end bracket the measured number.
By their numbers in this assay, from the lowest: compounds 2 and 3 (each within the scatter of the next); then compounds 4 and 1 (each within the scatter of the next).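

In this assay, pyridin-2-yl in place of phenyl on the amide-type nitrogen now also holds on the chloro core, a number 23.5 percentage points higher from compound 2 to compound 4 (beyond the scatter), so the change no longer rests on the nitro pair alone and reads alike on both cores: the same change on two cores in this assay, a number 20.9 percentage points lower (beyond the scatter) from compound 1 to compound 3 and a number 23.5 percentage points lower (beyond the scatter) from compound 4 to compound 2, 2.6 percentage points apart, within the scatter of two such steps. With the pyridin-2-yl amide, chloro in place of nitro again stays within the scatter, a number 3.6 percentage points lower from compound 1 to compound 4 (within the scatter), matching the phenyl amides: the same change on two cores in this assay, a number 6.2 percentage points higher (within the scatter) from compound 2 to compound 3 and a number 3.6 percentage points higher (within the scatter) from compound 4 to compound 1, 2.6 percentage points apart, within the scatter of two such steps.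

Going by these compounds, whether pyridin-3-yl, pyridin-4-yl or pyrimidin-2-yl on the same nitrogen would give the same step remains open. So does whether a core carrying an amine in place of chloro or nitro would follow these two cores.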